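From ethyl to (oxan-4-yl)methyl on the shared core

This account rests on a few compounds, and the source may have more. Where it says the series, first, only, none or still open, it means among the compounds named here.

In a physicochemical assay for lipophilicity, using the shake flask method, measured as octanol-water partition, at pH 7.4 (on this read-out lower numbers stand for lower lipophilicity and higher numbers for higher lipophilicity), compound 1 (`CC(C)Cn1cc(-c2ccnc3[nH]c(C4CCN(CC(=O)N(C)C)CC4)cc23)ccc1=O`) reads 2 and compound 2 (`CN(C)C(=O)CN1CCC(c2cc3c(-c4ccc(=O)n(C5CCOCC5)c4)ccnc3[nH]2)CC1`) reads 1.1 while compound 3 (`CCn1cc(-c2ccnc3[nH]c(C4CCN(CC(=O)N(C)C)CC4)cc23)ccc1=O`) reads 1.2 on the same scale. Compound 3 thus lies level with compound 2 and clearly under compound 1. Compound 4 (`CN(C)C(=O)CN1CCC(c2cc3c(-c4ccc(=O)n(CC5CCOCC5)c4)ccnc3[nH]2)CC1`) differs from compound 3 by oxan-4-yl in place of methyl on a saturated chain carbon bound to an aromatic nitrogen in one place: oxan-4-yl in place of methyl on a saturated chain carbon bound to an aromatic nitrogen. Going by the values given here, three measured steps bear on this change. At that same place, methyl in place of isopropyl gave a number 0.80 log units lower from compound 1 to compound 3 (beyond the scatter) in this series. On the aromatic nitrogen itself, oxan-4-yl in place of isobutyl gave a number 0.90 log units lower from compound 1 to compound 2 (beyond the scatter) in the same series, and ethyl in place of oxan-4-yl gave only a number 0.10 log units higher from compound 2 to compound 3 (within the scatter) between those two groups. Only a small upward move is therefore expected, estimated as a number 0.20 log units higher from compound 3 to compound 4 (within the scatter) and possibly not clear of the scatter. Compound 4 is estimated at 1.4 (1 to 1.8).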

Compound 4, distribution coefficient: 1.4
The estimate for compound 4 equals the measured number at the digits printed; the range from low to high includes it.
By their numbers in this assay, from the lowest: compounds 2, 3 and 4 (each within the scatter of the next); then compound 1.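

In this assay, (oxan-4-yl)methyl on the aromatic nitrogen cannot be told apart from ethyl, with a number 0.20 log units higher from compound 3 to compound 4 (within the scatter) despite the added six-membered ring and its hydrogen-bond acceptor. Nor can it be told apart from oxan-4-yl, with a number 0.30 log units higher from compound 2 to compound 4 (within the scatter) when the two groups are exchanged, while isobutyl still stands apart, with a number 0.60 log units lower from compound 1 to compound 4 (beyond the scatter) on the shared core. Nothing measured here gives a reason for these numbers.

What the compounds shown leave open is whether this level reading holds for other kinds of group at this place, such as an amine, a carboxylic acid or a longer chain carrying the same oxan-4-yl ring. They also leave open whether an unbranched propyl chain would read with ethyl or with isobutyl, and so where along the plain alkyl groups the numbers begin to part.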